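From 3-methoxyphenyl to 3-bromo-4-fluorophenyl on the amide nitrogen

A few compounds are considered here, and "the series" means these few. Any claim that something is new, unique, unknown or untested is made for them only; others in the source may bear on it.

In a functional assay on MCF7 cells (Homo sapiens) for inhibition, read by MTT assay, with a stated time of 72 h (a lower number here means a stronger inhibitor, a higher number a weaker inhibitor), compound 2 (`COc1cccc(NC(=O)C2CCN(C/C=C/c3ccccc3)CC2)c1`) gives 42700 nM as its measured value. Compound 1 (`O=C(Nc1ccccc1)C1CCN(C/C=C/c2ccccc2)CC1`) gives 60200 nM and lies within the scatter of compound 2, and compound 3 (`O=C(Nc1cccc(C(F)(F)F)c1)C1CCN(C/C=C/c2ccccc2)CC1`) gives 16100 nM and lies lower than both. Compound 4 (`O=C(Nc1ccc(F)c(Br)c1)C1CCN(C/C=C/c2ccccc2)CC1`) has 3-bromo-4-fluorophenyl in place of 3-methoxyphenyl on an amide-type nitrogen, a change counted as 3-bromo-4-fluorophenyl in place of 3-methoxyphenyl on an amide-type nitrogen and not yet measured. Among the compounds with values here, no measured compound carries this new group, so the evidence is indirect. Methoxy in place of hydrogen gave a 1.4-fold lower number from compound 1 to compound 2 (0.15 log units; within the scatter), whereas trifluoromethyl in place of hydrogen gave a 3.7-fold lower number from compound 1 to compound 3 (0.57 log units; beyond the scatter). Within the data shown here, the closest precedent is the replacement of the methoxy itself, which gave a 2.7-fold lower number from compound 2 to compound 3 (0.42 log units; beyond the scatter), so a modest move in the same direction is expected. The expected step, an estimate only, is a 2.0-fold lower number from compound 2 to compound 4 (0.31 log units; beyond the scatter). Compound 4 is expected at 21000 nM, with an estimated range from 9000 nM to 45000 nM.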

Compound 4, half-maximal inhibitory concentration: 13500 nM
Estimate against measurement, compound 4: 1.6-fold (0.19 log units) above, within the range that was stated.
By their numbers in this assay, from the lowest: compounds 4 and 3 (each within the scatter of the next); then compounds 2 and 1 (each within the scatter of the next).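

In this assay, the 3-bromo-4-fluorophenyl group on the amide-type nitrogen gives a 3.2-fold lower number from compound 2 to compound 4 (0.50 log units; beyond the scatter), showing that this position accepts a ring with two halogens in place of 3-methoxyphenyl. Against the unsubstituted phenyl the change gives a 4.5-fold lower number from compound 1 to compound 4 (0.65 log units; beyond the scatter), while compound 3 at 16100 nM and compound 4 at 13500 nM lie within the scatter of each other, so a second route from the phenyl of compound 1 reaches the same level as trifluoromethyl. No measurement shown explains why this change lowers the number.

The compounds shown leave open how much of the step belongs to the bromine and how much to the fluorine, since neither appears alone on the ring. They also leave open how an amine or a carboxylic acid on that ring would behave.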